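Urea to amide: what happens when the bridging nitrogen goes

The source may report more compounds than this note shows. Statements on the series, on what has been measured and on what is new or still open speak of the compounds shown alone.

Compound 3 `COc1cc(Cl)cc(-c2nn(-c3cccc(NC(=O)Nc4cccc(C(F)(F)F)c4)c3)cc2-c2ccncc2)c1` gives -18% in a functional assay on CCRF-CEM cells (Homo sapiens) for inhibition, read by sulforhodamine B assay, with a stated time of 48 h, tested at 100 uM; on this read-out higher numbers stand for a weaker effect at the one concentration tested and lower numbers for a stronger effect. Its number is the highest of the three measured compounds, but only the gap to compound 1 is meaningful: compound 1 `COc1cc(Cl)cc(-c2nn(-c3cccc(NC(=O)Nc4ccc(Cl)c(C(F)(F)F)c4)c3)cc2-c2ccncc2)c1` gives -29%, and a number 11 percentage points higher from compound 1 to compound 3 (beyond the scatter), whereas compound 2 `COc1cc(Cl)cc(-c2nn(-c3cccc(NC(=O)Nc4ccc(Cl)c(Cl)c4)c3)cc2-c2ccncc2)c1` gives -27% and a number 9 percentage points higher from compound 2 to compound 3 (within the scatter). Compound 4 `COc1cc(Cl)cc(-c2nn(-c3cccc(NC(=O)c4cccc(C(F)(F)F)c4)c3)cc2-c2ccncc2)c1` carries 3-(trifluoromethyl)phenyl in place of (3-(trifluoromethyl)phenyl)amino on a carbonyl carbon. The measured steps all change the outer ring, not the linker, so none bears directly on this swap. With nothing pointing either way, compound 4 is expected to stay close to compound 3, with no change at the digits printed from compound 3 to compound 4 (within the scatter), giving an estimated -18%, between -38% and 2%.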

Compound 4, a percentage reported as activity, at one concentration (the size of the read-out at that concentration, not a potency): 32%
The estimate for compound 4 lay 50 percentage points below the measured number, and the stated range ends below it.
By their numbers in this assay, from the lowest: compounds 1, 2 and 3 (each within the scatter of the next, the first and the last beyond it); then compound 4.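

In this assay, the link to the outer ring turns out to matter far more than the groups on that ring: replacing the urea with an amide gives a number 50 percentage points higher from compound 3 to compound 4 (beyond the scatter), much larger than any step among the three ureas. The gap is just as wide for the other two ureas, with a number 59 percentage points higher from compound 2 to compound 4 (beyond the scatter) and a number 61 percentage points higher from compound 1 to compound 4 (beyond the scatter), although these two steps also change the outer ring. Nothing shown explains this jump. On these data alone, it remains open whether the amide behaves the same with other outer rings, and whether a carbamate or a sulfonamide in place of the urea would follow the urea or the amide.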